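Terminal alkyne replacing the heptyl tail on the acetophenone core

The source may hold more compounds than are shown below. What is called first, only, known or untested is meant among the compounds shown, and "the series" means these compounds.

Compound 3 `C=CCc1cc(C(C)=O)c(O)cc1OCCCCCCC` stands lowest of the three numbers in an assay on isolated protein for binding affinity to leukotriene B4 receptor 1 (Homo sapiens), tested at 1 uM (a lower number here means less inhibition, a higher number more inhibition at the concentration tested (going by the name of the read-out)), with compound 3 giving 8%. Its nearest neighbour is compound 2 `C=CCc1cc(C(C)=O)c(O)cc1OCCCCC`, which in this assay gives 23%, and the furthest is compound 1 `C=CCc1cc(C(C)=O)c(O)cc1OCCCCCC#N`, which gives 41%. The steps run a number 15 percentage points lower from compound 2 to compound 3 (beyond the scatter), a number 33 percentage points lower from compound 1 to compound 3 (beyond the scatter) and a number 18 percentage points lower from compound 1 to compound 2 (beyond the scatter), so the cyano-bearing chain sits highest and the longest plain chain lowest.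

Compound 4 `C#CCCCCOc1cc(O)c(C(C)=O)cc1CC=C` differs from compound 3 by ethynyl in place of propyl on a saturated chain carbon, four bonds along the chain from an oxygen on an aromatic ring. The chain is shortened and a triple bond is introduced; the one measured chain that carries a triple bond, compound 1, gives the highest number, and removing two chain carbons, the step from compound 3 back toward compound 2, recovered part of the gap. Both steps point upward, so a rise beyond the scatter is expected, of the order of a number 22 percentage points higher from compound 3 to compound 4 (beyond the scatter). Compound 4 is therefore estimated at 30%, within 15% to 45%.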

Compound 4, a percentage reported as inhibition, at one concentration (the size of the read-out at that concentration, not a potency): 29%
Beside the measured number, compound 4's estimate is 1 percentage points above it, within the range that was stated.
By their numbers in this assay, from the lowest: compound 3; then compounds 2 and 4 (each within the scatter of the next); then compound 1.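

In this assay, ethynyl in place of propyl on this saturated chain carbon gives a number 21 percentage points higher from compound 3 to compound 4 (beyond the scatter) and shows that a chain ending in a triple bond between carbons can sit clear of the heptyl chain. Ethynyl in place of methyl gives a number 6 percentage points higher from compound 2 to compound 4 (within the scatter) and leaves compound 4 not separable from the plain chain of compound 2, so the gain over compound 3 cannot be assigned to the triple bond rather than to the shorter chain. Ethynyl in place of cyanomethyl gives a number 12 percentage points lower from compound 1 to compound 4 (beyond the scatter) and shows that the ethynyl end does not match the nitrile chain, although that step changes the end group and the chain length together.

Open, going by these compounds, is whether a longer chain ending in ethynyl, or a chain ending in a carboxylic acid or an amine, would hold or raise the number. No measurement at hand accounts for these differences.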